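Capping a Sulfonamide Nitrogen with Methyl

The compounds below may be only part of what the source reports. "The series", "measured", "known", "first", "only" and "open" are said of these compounds alone.

Three phenoxyacetic acids linked through an alkyne to a second aromatic ring have been measured in an assay on CHO cells for displacement of a labelled ligand from prostaglandin D2 receptor 2 (Homo sapiens), read by scintillation counting; a higher number here means a weaker inhibitor, a lower number a stronger inhibitor. Compound 1 `CCCS(=O)(=O)c1cccc(C#Cc2cc(F)ccc2OCC(=O)O)c1` carries a propylsulfonyl group and in this assay compound 1 gives 65 nM. Compound 3 `O=C(O)COc1ccc(Cl)cc1C#Cc1cccc(C(F)(F)F)c1` has a trifluoromethyl group instead, and in this assay compound 3 gives 92 nM. Compound 2 `CNS(=O)(=O)c1ccc(C)c(C#Cc2cc(Cl)ccc2OCC(=O)O)c1` bears a methylsulfamoyl group on a methyl-substituted ring, and in this assay compound 2 gives 10 nM, the lowest of the three numbers, with both the gap to compound 1 and the gap to compound 3 beyond the usual scatter.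

Compound 4 `Cc1ccc(S(=O)(=O)N(C)C)cc1C#Cc1cc(Cl)ccc1OCC(=O)O` differs from compound 2 in a single place: methyl in place of hydrogen on a sulfonamide nitrogen. Within the data shown here, no measured pair shows this exact change, so the expected size of the step is uncertain. Since compound 2 sits at 10 nM and the change is small, a modest weakening is expected, giving a step of a 2.5-fold higher number from compound 2 to compound 4 (0.40 log units; beyond the scatter). Compound 4 is estimated to give 25 nM, within a range from 8 nM to 80 nM.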

Compound 4, inhibition constant: 5 nM
Compound 4: middle estimate off by 5.0-fold (0.70 log units), on the high side, and the stated range ends above it.
By their numbers in this assay, from the lowest: compounds 4 and 2 (each within the scatter of the next); then compounds 1 and 3 (each within the scatter of the next).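

Putting methyl in place of hydrogen on the sulfonamide nitrogen gives a 2.0-fold lower number from compound 2 to compound 4 (0.30 log units; within the scatter) in this assay and so leaves compound 2 and compound 4 indistinguishable here. This is the first pair shown that differs in only one place, and it indicates that this nitrogen can carry a second methyl, with the hydrogen gone, without a loss of binding that this measurement can detect. Nothing available explains why the change is tolerated.

Still open, on these data alone, is how the position responds to a sulfonamide nitrogen bearing two hydrogens, or to an ethyl group or a longer chain on that nitrogen. It is also unknown whether a ring containing the nitrogen, such as a piperidine, would fit as well as the two methyl groups.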